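Dienone series: second trifluoromethyl on the aryl ring

The source may hold more compounds than are shown below. What is called first, only, known or untested is meant among the compounds shown, and "the series" means these compounds.

Measured so far:
compound 1 `CC1=C(/C=C/C(=O)/C=C/c2ccccc2C(F)(F)F)C(C)(C)CCC1O` — 3700 nM
compound 2 `CC1=C(/C=C/C(=O)/C=C/c2cccc(C(F)(F)F)c2)C(C)(C)CCC1O` — 3500 nM

Both compounds share one core and differ only in where the single trifluoromethyl sits on the aryl ring. In a functional assay on PC-3 cells (Homo sapiens) for cytotoxicity, read by MTT assay, with a stated time of 72 h (on this read-out lower numbers stand for stronger inhibition and higher numbers for weaker inhibition), compound 1 gives 3700 nM and compound 2 gives 3500 nM. The two numbers lie within the scatter of each other, so neither compound can be set ahead of the other on this read-out; compound 2 simply carries the smaller of two near-identical values.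

Compound 3 `CC1=C(/C=C/C(=O)/C=C/c2cc(C(F)(F)F)ccc2C(F)(F)F)C(C)(C)CCC1O` is not yet measured. It derives from compound 2 by trifluoromethyl in place of hydrogen on an aromatic carbon. Going by the values given here, no comparable single-site step between measured compounds exists in this set, so the size of this change must be guessed. Given that the two mono-substituted compounds sit at the same level, a second trifluoromethyl on the same ring is expected to move the number little, if at all, beyond the scatter; a modest shift in either direction would not surprise. Compound 3 is therefore estimated at 3000 nM in this assay, with a range of 1200 nM to 7500 nM, meaning an expected step of a 1.2-fold lower number from compound 2 to compound 3 (0.07 log units; within the scatter).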

Compound 3, half-maximal inhibitory concentration: 1900 nM
Compound 3: middle estimate off by 1.6-fold (0.20 log units), on the high side, and the stated range covers the measured number.
By their numbers in this assay, from the lowest: compounds 3, 2 and 1 (each within the scatter of the next).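

In this assay the second trifluoromethyl, on an aromatic carbon ortho to a large group and para to a trifluoromethyl group, produces a small step when compound 3 is read against the mono-substituted compound that shares the para trifluoromethyl pattern (a 1.8-fold lower number from compound 2 to compound 3 (0.27 log units; within the scatter)) and an equally small one when read against the other mono-substituted compound (a 1.9-fold lower number from compound 1 to compound 3 (0.29 log units; within the scatter)). Both steps stay inside the scatter, so this position accepts a second trifluoromethyl on the ring with no readable loss or gain, and the three compounds stand at one level on this read-out, which the two mono-substituted compounds alone could not show. Nothing in hand bears on what lies behind these small steps.

Still open, going by these compounds, is whether this position responds at all: a methoxy, a nitrile, an amine or a carboxylic acid on the same aromatic carbon might give a step beyond the scatter, or might leave the number at this level as trifluoromethyl does. Also open, on these data alone, is whether the hydroxyl on the shared core matters more to this read-out than anything on the aryl ring.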